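A Fluoro for Methoxy Swap on a Shared Core

This account rests on a few compounds, and the source may have more. Where it says the series, first, only, none or still open, it means among the compounds named here.

Compound 1, `CN(C(=O)NC(=O)c1ccc(F)c(F)c1)c1nc(C(F)(F)F)c(C(=O)N/N=C/c2ccc([N+](=O)[O-])cc2)s1`, gives 6.23 ug/mL in a functional assay on HepG2 cells (Homo sapiens) for inhibition, read by MTT assay, with a stated time of 72 h; a lower number here means a stronger inhibitor, a higher number a weaker inhibitor.
Compound 2, `COc1ccc(/C=N/NC(=O)c2sc(N(C)C(=O)NC(=O)c3c(F)cccc3F)nc2C)cc1`, gives 22.7 ug/mL in this assay.

Of the two numbers measured, compound 2 stands at the higher one, the weaker inhibitor; compound 1 sits at a number beyond the scatter below it. Going by the values given here, no pair among the measured compounds differs in just one place, so no single structural change has a measured step attached to it. Compound 3, `Cc1nc(N(C)C(=O)NC(=O)c2c(F)cccc2F)sc1C(=O)N/N=C/c1ccc(F)cc1`, differs from compound 2 as follows: fluoro in place of methoxy on an aromatic carbon. Among the compounds with values here, nothing among the measured compounds shows how such a change moves this assay, and the expectation rests only on the small size of the change and on the rest of the molecule being unchanged. The step of a 1.1-fold lower number from compound 2 to compound 3 (0.05 log units; within the scatter) is expected to be modest, a shift that may not exceed the scatter. Compound 3 is therefore estimated at 20 ug/mL, within 8 ug/mL to 50 ug/mL.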

Compound 3, half-maximal inhibitory concentration: > 100 ug/mL
Compound 3 was reported as a limit (the forecaster's own chance of this, stated with the estimate: 5%); middle value at least 5.0-fold (0.69 log units) from the limit.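

At this position, on an aromatic carbon para to a large group, the change from 4-methoxyphenyl to 4-fluorophenyl is not a small one in this assay: fluoro in place of methoxy gives an at least 4.4-fold higher number from compound 2 to compound 3 (0.64 log units; beyond the scatter). Compound 3 is reported as a limit and not as a number: the limit of > 100 ug/mL in this assay, at which 1 of the 3 values shown sits. The earlier compounds shown here, no two of which differ in just one place, could not show this, and the step now shows that a single substituent at this position on the shared core can carry the direction of the read-out toward weaker inhibition.

The compounds shown leave open how far past the limit compound 3 lies, and whether the step follows the loss of methoxy or the arrival of fluoro. From the compounds shown here alone, whether a hydroxy group, an amine or a chloro at the same place would stand with methoxy or with fluoro also remains open.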